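Ethyl to 2-Fluorophenyl: Expected Effect on Growth Inhibition

A few compounds are considered here, and "the series" means these few. Any claim that something is new, unique, unknown or untested is made for them only; others in the source may bear on it.

Compound 1 `N#Cc1ccc(Nc2nc(Oc3ccnc4ccccc34)nc(N3CCN(c4ccccc4Cl)CC3)n2)cc1C(F)(F)F`: > 100000 nM
Compound 2 `CCN1CCN(c2nc(Nc3ccc(C#N)c(C(F)(F)F)c3)nc(Oc3ccnc4ccccc34)n2)CC1`: > 100000 nM
Compound 3 `COc1ccc(CN2CCN(c3nc(Nc4ccc(C#N)c(C(F)(F)F)c4)nc(Oc4ccnc5ccccc45)n3)CC2)c(OC)c1OC`: > 100000 nM
Compound 4 `N#Cc1ccc(Nc2nc(Oc3ccnc4ccccc34)nc(N3CCN(c4ccccc4F)CC3)n2)cc1C(F)(F)F`: not yet measured

In a functional assay on DU-145 cells (Homo sapiens) for cytotoxicity, read by sulforhodamine B assay, with a stated time of 48 h (on this read-out lower numbers stand for stronger inhibition of growth and higher numbers for weaker inhibition of growth), compound 2 gives only a limit, > 100000 nM, and no number. Compound 1 and compound 3 likewise sit at a limit, as the limit of > 100000 nM in this assay, at which 3 of the 3 values shown sit, records. Compound 4 differs from compound 2 by 2-fluorophenyl in place of ethyl on an amine nitrogen in a ring. The step that the two limits leave unreadable from compound 1 to compound 2 touches this same position, and a step that the two limits leave unreadable from compound 2 to compound 3 touches a neighbouring one, but with every value at the limit neither step has a readable size. Compound 1, which already carries a 2-chlorophenyl at this position, shows no measurable growth inhibition. Compound 4 is therefore expected to give 150000 nM, within 40000 nM to 600000 nM, most likely again a limit. The step that the limit leaves unreadable from compound 2 to compound 4 is expected to be none beyond the scatter.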

Compound 4, concentration for total growth inhibition: > 100000 nM
Compound 4 ended at the assay's limit; the forecaster's own chance of this, stated with the estimate: 80%; the middle value is on the limit's open side.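

Compound 4 gives no number, so its steps from compound 1 and compound 2 cannot be read, and all the compounds stop at one limit: the limit of > 100000 nM in this assay, at which 4 of the 4 values shown sit. The compounds shown leave open whether any group on this ring nitrogen changes growth inhibition.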